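This account rests on a few compounds, and the source may have more. Where it says the series, first, only, none or still open, it means among the compounds named here.

Notes on the series, step from compound 2 to compound 3.

Two compounds in the series have a number in an assay on isolated protein for binding affinity to Equilibrative nucleoside transporter 1 (Homo sapiens); a higher number here means a weaker inhibitor, a lower number a stronger inhibitor. Compound 1 `OC[C@H]1O[C@@H](n2cnc3c(CSc4cccc(I)c4)ncnc32)[C@H](O)[C@@H]1O` gives 245 nM. Compound 2 `OC[C@H]1O[C@@H](n2cnc3c(CSc4ccc(I)cc4)ncnc32)[C@H](O)[C@@H]1O` gives 69.2 nM. Going by the values given here, the one measured step, a 3.5-fold lower number from compound 1 to compound 2 (0.55 log units; beyond the scatter), concerns only where the iodo sits on the phenyl ring. Compound 2 thus holds the lowest number of the two, and compound 1 is the nearest neighbour.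

Compound 3 `COc1ccc(SCc2ncnc3c2ncn3[C@@H]2O[C@H](CO)[C@@H](O)[C@H]2O)cc1` keeps the shared core and the sulfur link of compound 2 and differs in one place: methoxy in place of iodo on an aromatic carbon, on an aromatic carbon of the six-membered carbon ring, para to a large group. Among the compounds with values here, no measured step in this assay exchanges the iodo for another group; the step from compound 1 to compound 2 speaks only to the position of the iodo and not to its identity. The direction of the change in this assay is therefore open, and the expected step of a 2.2-fold higher number from compound 2 to compound 3 (0.34 log units; beyond the scatter) is set near no change, with a wide band on both sides. The number for compound 3 is estimated at 150 nM, expected to fall between 30 nM and 800 nM.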

Compound 3, half-maximal inhibitory concentration: 617 nM
Beside the measured number, compound 3's estimate is 4.1-fold (0.61 log units) below it; measured number inside the range.
By their numbers in this assay, from the lowest: compound 2; then compound 1; then compound 3.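

In this assay, going by these compounds alone, the first exchange of the iodo itself gives an 8.9-fold higher number from compound 2 to compound 3 (0.95 log units; beyond the scatter), so the number at this position depends on which group sits on the aromatic carbon para to a large group, and not only on where the iodo is placed. The 4-methoxyphenyl group on the sulfur also compares poorly with the 3-iodophenyl group, with a 2.5-fold higher number from compound 1 to compound 3 (0.40 log units; beyond the scatter), so among these three compounds compound 2 holds the lowest number, and its steps to the other two lie beyond the scatter. No evidence is at hand that accounts for this change.

Two groups at this position cannot separate the effect of losing the iodo from that of bringing in the methoxy, and a bromo, a chloro, a methyl, an amine or a carboxylic acid in the same place would show whether compound 2 stands alone or belongs to a wider trend. Also open, going by these compounds, is whether a longer chain, such as ethoxy or propoxy, moves the number further from that of compound 3 or back towards that of compound 2.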